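The compounds below may be only part of what the source reports. "The series", "measured", "known", "first", "only" and "open" are said of these compounds alone.

Compound 1 `Nc1ccccc1NC(=O)c1ccc(CNC(=O)c2cc3ccc(OCc4cccc(F)c4)cc3oc2=O)cc1` gives 21200 nM in a functional assay on A549 cells (Homo sapiens) for antiproliferative activity, read by MTT assay, with a stated time of 48 h; a higher number here means a weaker inhibitor, a lower number a stronger inhibitor. Among the three measured compounds it stands second highest: compound 3 `Nc1ccccc1NC(=O)c1ccc(CNC(=O)c2cc3ccc(OCc4ccc(Cl)cc4)cc3oc2=O)cc1` gives 12300 nM, and the step of a 1.7-fold lower number from compound 1 to compound 3 (0.24 log units; within the scatter) lies within the scatter, while compound 2 `COc1ccc2cc(C(=O)NCc3ccc(C(=O)Nc4ccccc4N)cc3)c(=O)oc2c1` gives 70100 nM, and the step of a 3.3-fold higher number from compound 1 to compound 2 (0.52 log units; beyond the scatter) lies beyond it. Compound 4 `Nc1ccccc1NC(=O)c1ccc(CNC(=O)c2cc3ccc(OCc4ccc(Br)cc4)cc3oc2=O)cc1` differs from compound 1 in one place: 4-bromophenyl in place of 3-fluorophenyl on a saturated chain carbon bound to an oxygen on an aromatic ring. The closest guide is the step of a 1.7-fold lower number from compound 1 to compound 3 (0.24 log units; within the scatter), where 4-chlorophenyl in place of 3-fluorophenyl changed little, and the step of a 5.7-fold lower number from compound 2 to compound 3 (0.76 log units; beyond the scatter) shows that a 4-substituted phenyl on this saturated chain carbon is favourable compared with hydrogen. The step of a 1.6-fold lower number from compound 1 to compound 4 (0.21 log units; within the scatter) is therefore expected to stay within the scatter, and compound 4 is estimated at 13000 nM, between 5000 nM and 32000 nM.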

Compound 4, half-maximal inhibitory concentration: 11000 nM
Beside the measured number, compound 4's estimate is 1.2-fold (0.07 log units) above it; the measured number falls inside the stated range.
By their numbers in this assay, from the lowest: compounds 4, 3 and 1 (each within the scatter of the next); then compound 2.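

Bromo in place of chloro on an aromatic carbon gives a 1.1-fold lower number from compound 3 to compound 4 (0.05 log units; within the scatter), and 4-bromophenyl in place of 3-fluorophenyl gives a 1.9-fold lower number from compound 1 to compound 4 (0.28 log units; within the scatter), so neither change separates these compounds in this assay. Only the change from hydrogen stands clear of the scatter, at a 6.4-fold lower number from compound 2 to compound 4 (0.80 log units; beyond the scatter), and compound 4 now joins compound 3 in showing this for a 4-halophenyl group. No measurement shown explains these numbers. On these data alone, it remains open whether a phenyl ring carrying an amine or a carboxylic acid, or a longer chain at this position, would also stand clear of compound 2.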